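The source may hold more compounds than are shown below. What is called first, only, known or untested is meant among the compounds shown, and "the series" means these compounds.

In a functional assay on KBVIN cells (Homo sapiens) for antiproliferative activity, read by sulforhodamine B assay, with a stated time of 3 days (a lower number here means that less compound is needed, a higher number that more compound is needed for the effect), compound 1 `CCC1=C(O)c2c(oc(-c3ccc(C)cc3)cc2=O)C(CC)(CC)C1=O` gives 0.08 uM, compound 2 `CCC1=C(O)c2c(oc(-c3ccc(C)c(F)c3)cc2=O)C(CC)(CC)C1=O` gives 2.95 uM and compound 3 `CCC1=C(O)c2c(oc(-c3ccc(OC)c(C)c3)cc2=O)C(CC)(CC)C1=O` gives 0.1 uM. Compound 3 therefore sits level with compound 1, within the usual scatter, and far below compound 2. Compound 4 `CCC1=C(O)c2c(oc(-c3ccc(OC)c(Cl)c3)cc2=O)C(CC)(CC)C1=O` has not yet been measured. It differs from compound 3 by chloro in place of methyl on an aromatic carbon, ortho to a methoxy group (chloro in place of methyl on an aromatic carbon).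

For the measured compounds named here, two measured steps bear on this change. Putting 4-methoxy-3-methylphenyl in place of 4-methylphenyl gave a 1.3-fold higher number from compound 1 to compound 3 (0.10 log units; within the scatter), so that swap left the number within the scatter. Fluoro in place of hydrogen on an aromatic carbon, however, gave a 37-fold higher number from compound 1 to compound 2 (1.57 log units; beyond the scatter), a large step. Going by the values given here, compound 2 is the only measured compound carrying a halogen, and its change is not the same as this one, so it is only a loose guide. A moderate rise is expected, smaller than the fluoro step, and the estimated step is a 4.0-fold higher number from compound 3 to compound 4 (0.60 log units; beyond the scatter). For compound 4 the expected value is 0.4 uM, with an estimated range of 0.08 uM to 2 uM.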

Compound 4, concentration for half-maximal effect: 1.37 uM
For compound 4 the middle estimate is 3.4-fold (0.53 log units) below the measured one, within the range that was stated.
By their numbers in this assay, from the lowest: compounds 1 and 3 (each within the scatter of the next); then compound 4; then compound 2.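

In this assay, chloro in place of methyl on an aromatic carbon, ortho to a methoxy group, gave a 14-fold higher number from compound 3 to compound 4 (1.14 log units; beyond the scatter) and so showed that this position responds strongly to what sits on it, even though the methyl-bearing compound 3 had stayed level with compound 1. The chloro compound also lies well away from compound 1, with a 17-fold higher number from compound 1 to compound 4 (1.23 log units; beyond the scatter) as the step between them. Among these four compounds, the two carrying a halogen have the higher numbers, yet they still differ, with a 2.2-fold lower number from compound 2 to compound 4 (0.33 log units; beyond the scatter) as a modest step, and nothing here offers an explanation for the rise.

From the compounds shown here alone, whether chloro would cost as much alongside a methyl group in place of the methoxy group remains open. So does the effect of a bromo group, an amine or a propyl chain at this position.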